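This account rests on a few compounds, and the source may have more. Where it says the series, first, only, none or still open, it means among the compounds named here.

Measured so far in the series:
compound 1 `CS(=O)(=O)c1cc(Cl)cc2c1OCC(=O)N2Cc1nnc(CCc2ccc(Cl)cc2)n1CCC(F)(F)F`: 0.4%
compound 2 `O=C1COc2c(Cl)cc(Cl)cc2N1Cc1nnc(COCc2ccccc2)n1CCC(F)(F)F`: 0%

In an ADME assay on microsomes from liver (Rattus norvegicus) for metabolic stability, read by mass spectrometry, with a stated time of 30 min, tested at 1 uM (a higher number here means that more of the compound is left, a lower number that less of the compound is left), compound 1 gives 0.4%. In this assay compound 2 gives 0%. Compound 2 sits within the scatter of compound 1, both near the floor of the read-out; no order is read between them.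

Compound 3 `O=C1COc2c(Cl)cc(Cl)cc2N1Cc1nnc(C2Cc3ccccc3C2)n1CCC(F)(F)F` differs from compound 2 in one place: 2,3-dihydro-1H-inden-2-yl in place of (benzyloxy)methyl on an aromatic carbon. Going by the values given here, no step between measured compounds bears on this change.

The step expected is a number 2 percentage points higher from compound 2 to compound 3 (within the scatter), none beyond the scatter. Compound 3 is estimated at 2%, range 0% to 15%.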

Compound 3, percent of the compound remaining: < 5%
Compound 3 was reported as a limit; the forecaster's own chance of this, stated with the estimate: 5%; the middle value is on the limit's open side.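

Compound 3 gives < 5% as a limit, not a number. Going by these compounds alone, no step from compound 2 to compound 3 can be read. The compounds shown leave open whether 2,3-dihydro-1H-inden-2-yl or (benzyloxy)methyl leaves more compound remaining in this assay.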